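A Chloro Substituent Added to the Shared Core

This account rests on a few compounds, and the source may have more. Where it says the series, first, only, none or still open, it means among the compounds named here.

Two compounds have been measured in a functional assay on MDA-MB-468 cells (Homo sapiens) for inhibition, read by sulforhodamine B assay, with a stated time of 48 h, tested at 10 uM; a higher number here means more inhibition of growth at the concentration tested, a lower number less inhibition of growth:
compound 1 `c1ccc(-c2nc3sc(-c4ccccc4)cn3n2)cc1` gives 14%
compound 2 `COc1ccc(-c2nc3sc(-c4ccc(Cl)cc4)cn3n2)cc1` gives 66.6%

Compound 1 stands lowest of these two numbers. Compound 2 differs from it in two places at once, and its value lies beyond the scatter above that of compound 1, so at least one of those two changes raises growth inhibition; the two values alone cannot say which one, or whether both do.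

Compound 3 `Clc1ccc(-c2cn3nc(-c4ccccc4)nc3s2)cc1` has not yet been measured in this assay. Among the measured compounds shown here, it carries only one of the two changes seen in compound 2: chloro in place of hydrogen on an aromatic carbon. For the measured compounds named here, no measured pair differs in exactly this place, so the size of the step from compound 1 to compound 3 has to be expected rather than read off. The value of compound 2 gives the only anchor, because compound 2 gives 66.6% while carrying this change together with a second one. A rise beyond the scatter is expected, of about a number 24 percentage points higher from compound 1 to compound 3 (beyond the scatter). Compound 3 is estimated to give 38%, with a range from 15% to 62%.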

Compound 3, percent growth inhibition at one concentration: 57%
Estimate against measurement, compound 3: 19 percentage points below; measured number inside the range.
By their numbers in this assay, from the lowest: compound 1; then compounds 3 and 2 (each within the scatter of the next).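

Replacing phenyl with 4-chlorophenyl, which places chloro para to a large group, gives a number 43 percentage points higher from compound 1 to compound 3 (beyond the scatter) in this assay and so settles what the first two compounds could not: this single change is enough on its own to raise growth inhibition by a large step. The pair that differs only by a methoxy group gives a number 9.6 percentage points lower from compound 2 to compound 3 (within the scatter) and thus shows that, with chloro in place, the methoxy adds nothing that can be told apart from the usual scatter, so chloro alone can account for the rise seen earlier. Nothing available explains why this change has such an effect on these cells.

The compounds shown leave open whether the rise belongs to chloro itself or would also come with another group at the same place, such as fluoro, bromo, methyl or an amine. They also leave open what methoxy does on the core without chloro, as it appears here only together with that group.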